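The compounds below may be only part of what the source reports. "The series", "measured", "known", "first", "only" and "open" are said of these compounds alone.

For the measured compounds named here, in an ADME assay on the whole organism (Rattus norvegicus, strain Sprague-Dawley) for pharmacokinetics, read by LC-MS, with a stated time of 48 h, at a dose of 5 mg/kg by the intravenous route (on this read-out lower numbers stand for lower exposure and higher numbers for higher exposure at the dose given), compound 1 `CC#CCn1c(N2CCC[C@@H](N)C2)nc2c1c(=O)n(Cc1ccc(Br)cc1C(=O)O)c(=O)n2C` gives 124000 nM and compound 2 `CC#CCn1c(N2CCC[C@@H](N)C2)nc2c1c(=O)n(Cc1cc(OC)ccc1C(=O)O)c(=O)n2C` gives 25300 nM, the lower of the two numbers so far. Compound 3 `CC#CCn1c(N2CCC[C@@H](N)C2)nc2c1c(=O)n(Cc1ccc(Cl)cc1C(=O)O)c(=O)n2C` differs from compound 2 in one place: 2-carboxy-4-chlorophenyl in place of 2-carboxy-5-methoxyphenyl on a saturated chain carbon bound to an aromatic nitrogen. Going by the values given here, the entering 2-carboxy-4-chlorophenyl carries chlorine in place of the bromine in the 4-bromo-2-carboxyphenyl of compound 1, so the one measured step bears on it: a 4.9-fold lower number from compound 1 to compound 2 (0.69 log units; beyond the scatter). Read backwards, that step suggests a rise in this assay of similar or slightly smaller size, and the expected step is a 3.6-fold higher number from compound 2 to compound 3 (0.55 log units; beyond the scatter). For compound 3 the estimated value is 90000 nM, with an expected range from 40000 nM to 190000 nM.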

Compound 3, maximal plasma concentration: 63000 nM
For compound 3 the middle estimate is 1.4-fold (0.15 log units) above the measured one; measured number inside the range.
By their numbers in this assay, from the lowest: compound 2; then compounds 3 and 1 (each within the scatter of the next).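

In this assay the change to 2-carboxy-4-chlorophenyl gives a 2.5-fold higher number from compound 2 to compound 3 (0.40 log units; beyond the scatter) and this lies beyond the scatter, so the ring substituent on this chain carbon does shift the number. Chloro in place of bromo on an aromatic carbon gives a 2.0-fold lower number from compound 1 to compound 3 (0.29 log units; within the scatter) and this lies within the scatter, so these two halogens cannot be told apart in this read-out. Nothing measured here gives a reason for these numbers.

The compounds shown do not separate the effect of the methoxy group itself from that of its different place on the ring. On these data alone, how a fluoro, a nitrile or an amine would read in place of these groups also stays open.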